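A few compounds are considered here, and "the series" means these few. Any claim that something is new, unique, unknown or untested is made for them only; others in the source may bear on it.

Of the compounds shown here, three sharing one core have been measured so far in a functional assay on SHEP cells (Homo sapiens) for antiproliferative activity, read by spectrophotometry and resazurin assay, with a stated time of 72 h; a higher number here means a weaker inhibitor, a lower number a stronger inhibitor. Compound 1 (`CC(=O)CC1Oc2cc(O)ccc2C=C1c1ccc(O)cc1`) gives 124000 nM there, compound 2 (`CC(C)CC(=O)CC1Oc2cc(O)ccc2C=C1c1ccc(O)cc1`) gives 139000 nM there, and compound 3 (`O=C(CC1Oc2cc(O)ccc2C=C1c1ccc(O)cc1)c1ccccc1`) gives 102000 nM there. Compound 3 thus stands within the scatter of both others, and no order can be drawn among the three.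

Compound 4 (`Cc1ccc(C(=O)CC2Oc3cc(O)ccc3C=C2c2ccc(O)cc2)cc1`) differs from compound 3 by one change, phenyl to 4-methylphenyl on the carbonyl carbon (methyl in place of hydrogen on an aromatic carbon). Within the data shown here, no measured step shows this change itself. The closest evidence comes from changes of the group on that same carbonyl carbon, with a 1.2-fold lower number from compound 1 to compound 3 (0.08 log units; within the scatter) for phenyl in place of methyl and a 1.4-fold lower number from compound 2 to compound 3 (0.13 log units; within the scatter) for phenyl in place of isobutyl. Further along the chain, isopropyl in place of hydrogen gave a 1.1-fold higher number from compound 1 to compound 2 (0.05 log units; within the scatter) in the same read-out. All three steps stay within the scatter, so none of them points to a direction for the new methyl.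

Starting from compound 3 at 102000 nM as the reference, no step beyond the scatter is expected in this assay for this change. The expected step is a 1.1-fold lower number from compound 3 to compound 4 (0.03 log units; within the scatter) on this estimate. The estimated value for compound 4 is 95000 nM within an expected range of 50000 nM to 160000 nM once it is measured.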

Compound 4, half-maximal inhibitory concentration: 60000 nM
The estimate for compound 4 lay 1.6-fold (0.20 log units) above the measured number; measured number inside the range.
By their numbers in this assay, from the lowest: compounds 4, 3, 1 and 2 (each within the scatter of the next, the first and the last beyond it).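

In this assay, methyl in place of hydrogen on an aromatic carbon, para to a large group, gives a 1.7-fold lower number from compound 3 to compound 4 (0.23 log units; within the scatter) and so does not by itself establish a change at this position. Among these compounds, the group on the carbonyl carbon nevertheless now separates compounds for the first time: 4-methylphenyl in place of isobutyl gives a 2.3-fold lower number from compound 2 to compound 4 (0.36 log units; beyond the scatter) and 4-methylphenyl in place of methyl gives a 2.1-fold lower number from compound 1 to compound 4 (0.32 log units; beyond the scatter), both modest, whereas phenyl in place of either group had stayed within the scatter. No supporting measurement bears on why these steps arise.

From the compounds shown here alone, whether a methoxy group, a chlorine atom or a trifluoromethyl group on the same aromatic carbon would move the number at all remains open, as does the effect of a methyl group on another carbon of that ring. Also open, going by these compounds, is what an amine or a carboxylic acid on that ring, or a longer chain on the carbonyl carbon in place of the 4-methylphenyl group, would give in this assay on the shared core.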